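Piperazine-linked triazole series: dichlorophenyl swap on a second core

This account rests on a few compounds, and the source may have more. Where it says the series, first, only, none or still open, it means among the compounds named here.

Compound 1 `COc1ccccc1N1CCN(CCCCc2cn(-c3ccc4ccccc4c3)nn2)CC1` and compound 3 `COc1ccccc1N1CCN(CCCCn2cc(-c3ccc4ncccc4c3)nn2)CC1` are built on different cores; the difference between the two cores is not broken down here. In an assay on HEK293 cells for displacement of a labelled ligand from D(4) dopamine receptor (Homo sapiens), read by scintillation counting, with a stated time of 1 h (a lower number here means a stronger inhibitor, a higher number a weaker inhibitor), compound 1 gives 299 nM and compound 3 gives 269 nM, a gap within the scatter. Compound 2 `Clc1cccc(N2CCN(CCCCn3cc(-c4ccc5ncccc5c4)nn3)CC2)c1Cl` returns only a limit in this assay, > 1000 nM; that value is the limit of > 1000 nM in this assay, at which 1 of the 3 values shown sits. The change 2,3-dichlorophenyl in place of 2-methoxyphenyl on an amine nitrogen in a ring therefore produced an at least 3.7-fold higher number from compound 3 to compound 2 (0.57 log units; beyond the scatter). Compound 4 `Clc1cccc(N2CCN(CCCCc3cn(-c4ccc5ccccc5c4)nn3)CC2)c1Cl` carries the same change on the core of compound 1, (2,3-dichlorophenyl in place of 2-methoxyphenyl on an amine nitrogen in a ring), at a place described in the same words. Because the same change gave an at least 3.7-fold higher number from compound 3 to compound 2 (0.57 log units; beyond the scatter), compound 4 is expected to weaken by a comparable margin, an estimated 5.0-fold higher number from compound 1 to compound 4 (0.70 log units; beyond the scatter). Compound 4 is thus estimated at 1500 nM in this assay, with a real chance that only a limit is reported.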

Compound 4, inhibition constant: > 2000 nM
Compound 4: no number, only a limit; the forecaster's own chance of this, stated with the estimate: 65%; at least 1.3-fold (0.12 log units) between middle value and limit.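

In this assay compound 4 returns only a limit, > 2000 nM. Placing 2,3-dichlorophenyl in place of 2-methoxyphenyl on the core of compound 1 gives an at least 6.6-fold higher number from compound 1 to compound 4 (0.82 log units; beyond the scatter), so the change carries over in direction to a second core. This holds for these two pairs only and gives no transferable size for the step: the same change on two cores in this assay, an at least 3.7-fold higher number (0.57 log units; beyond the scatter) from compound 3 to compound 2 and an at least 6.6-fold higher number (0.82 log units; beyond the scatter) from compound 1 to compound 4; the limit leaves it open whether they differ

Still open, as far as these compounds go, is how a plain phenyl or a 2-chlorophenyl on the same amine nitrogen in a ring would read in this assay on either core. Also open, from the compounds shown here alone, is whether a longer chain would alter the effect of the change.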